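A phenylsulfonyl swap on compound 2

The source may report more compounds than this note shows. Statements on the series, on what has been measured and on what is new or still open speak of the compounds shown alone.

In a physicochemical assay for solubility (on this read-out higher numbers stand for higher solubility and lower numbers for lower solubility), compound 1 `O=C(c1cccnc1)N1CCC(NS(=O)(=O)c2cc(S(=O)(=O)c3ccccc3)ccc2C(F)(F)F)CC1` gives 50000 nM, and compound 2 `CN(C)c1ccc(C(=O)N2CCC(NS(=O)(=O)c3cc(S(=O)(=O)c4ccccc4)ccc3C(F)(F)F)CC2)cn1` gives 12500 nM, the lower of the two numbers. Compound 3 `O=S(=O)(NC1CCN(S(=O)(=O)c2ccccc2)CC1)c1cc(S(=O)(=O)c2ccccc2)ccc1C(F)(F)F`, still unmeasured, carries phenylsulfonyl in place of (6-(dimethylamino)pyridin-3-yl)carbonyl on an amine nitrogen in a ring. Going by the values given here, only one measured step bears on this: a 4.0-fold lower number from compound 1 to compound 2 (0.60 log units; beyond the scatter), a modest change made by dimethylamino in place of hydrogen on an aromatic carbon. It does not cover replacing the whole group, so the guidance is weak. The expected change is a modest one, a 2.5-fold lower number from compound 2 to compound 3 (0.40 log units; beyond the scatter). For compound 3 the estimate is 5000 nM, with an expected range from 1000 nM to 20000 nM.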

Compound 3, solubility: 25000 nM
Compound 3: middle estimate off by 5.0-fold (0.70 log units), on the low side; the whole stated range lies below it.
By their numbers in this assay, from the lowest: compounds 2, 3 and 1 (each within the scatter of the next, the first and the last beyond it).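

In this assay the swap to phenylsulfonyl on this amine nitrogen in a ring gives a 2.0-fold higher number from compound 2 to compound 3 (0.30 log units; within the scatter) when (6-(dimethylamino)pyridin-3-yl)carbonyl leaves, and a 2.0-fold lower number from compound 1 to compound 3 (0.30 log units; within the scatter) when (pyridin-3-yl)carbonyl leaves. So phenylsulfonyl can stand in place of either carbonyl group with no step beyond the scatter, although compound 1 and compound 2 lie beyond the scatter of each other. Nothing available here explains this result. As far as these compounds go, whether methylsulfonyl or a chain ending in an amine on that nitrogen would give a similar number remains open.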